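The compounds below may be only part of what the source reports. "The series", "measured", "known", "first", "only" and "open" are said of these compounds alone.

Of the compounds shown here, three have so far been measured in an in vitro functional assay on HEK293 cells for antagonist activity at melanin-concentrating hormone receptor 1 (Homo sapiens); a higher number here means a larger maximal response, a lower number a smaller maximal response. Compound 1 `Cc1ccc(CN2CCC(NC(=O)NCc3ccc(-c4ccc(F)cc4)cc3)CC2)cc1` gives 105%. Compound 2 `COc1ccc(-c2ccc(CN(CCC3CCN(Cc4ccc(C)cc4)CC3)C(=O)NC(C)(C)COC(C)=O)cc2)cc1` gives 112%, and compound 3 `CC(=O)OCC(C)(C)NC(=O)N(CCC1CCN(Cc2ccc(C)cc2)CC1)Cc1ccc(-c2ccccc2)cc1` gives 102%, the lowest of the three numbers, although its gaps to compound 1 and to compound 2 both lie within the scatter. For the measured compounds named here, the only single-place step among them, a number 10 percentage points lower from compound 2 to compound 3 (within the scatter), also stays within the scatter. Compound 4 `Cc1ccc(CN2CCC(CCN(Cc3ccc(-c4ccccc4)cc3)C(=O)NC(C)(C)CO)CC2)cc1` differs from compound 3 by hydrogen in place of acetyl on an oxygen on a saturated carbon. Going by the values given here, no measured step concerns this change, and the one single-place step available, which touches an aromatic substituent, gives little guidance. Among the compounds with values here, since every value so far sits close together, the expected step of a number 1 percentage points higher from compound 3 to compound 4 (within the scatter) is not beyond the scatter. Compound 4 is therefore expected to give 103%, with a range from 90% to 118%.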

Compound 4, largest response reached (reported as Imax), in percent of the reference or control that the assay uses: 105%
Compound 4: the middle estimate sits 2 percentage points below what was measured; measured number inside the range.
By their numbers in this assay, from the lowest: compounds 3, 1, 4 and 2 (each within the scatter of the next).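

In this assay, for the compounds shown here, the change from acetoxy to hydroxy on the 1-(acetoxymethyl)-1-methylethyl group gives a number 3 percentage points higher from compound 3 to compound 4 (within the scatter) and is the first step measured at this oxygen. Losing the acetyl, with its 3 heavy atoms, therefore leaves the maximal response within the scatter in this pair. No measurement here offers an explanation for this result. As far as these compounds go, whether an amine, a methyl ether or a carboxylic acid in place of the hydroxy would also stay within the scatter remains open. So does the effect of the same change alongside the methoxy of compound 2.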